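The source may hold more compounds than are shown below. What is called first, only, known or untested is meant among the compounds shown, and "the series" means these compounds.

Three compounds built on one shared core have been run through a functional assay on HT-29 cells (Homo sapiens) for cytotoxicity, read by MTT assay, with a stated time of 72 h; on this read-out lower numbers stand for stronger inhibition and higher numbers for weaker inhibition. Compound 1 `COc1cc2c(Oc3ccc(NC(=O)N/N=C/c4ccc(Cl)cc4Cl)cc3F)ccnc2cc1OCCCN1CCCCC1` gives 370 nM. Compound 2 `COc1cc2c(Oc3ccc(NC(=O)N/N=C/c4ccc(N(C)C)cc4)cc3F)ccnc2cc1OCCCN1CCCCC1` gives 1000 nM. Compound 3 `COc1cc2c(Oc3ccc(NC(=O)N/N=C/c4ccc(O)cc4)cc3F)ccnc2cc1OCCCN1CCCCC1` gives 470 nM, which places it second highest of the three numbers, nearest to compound 1 and furthest from compound 2. The step of a 1.3-fold higher number from compound 1 to compound 3 (0.10 log units; within the scatter) lies within the scatter, whereas a 2.7-fold higher number from compound 1 to compound 2 (0.43 log units; beyond the scatter) and a 2.1-fold lower number from compound 2 to compound 3 (0.33 log units; beyond the scatter) are modest. Compound 4 `COc1cc2c(Oc3ccc(NC(=O)N/N=C/c4cc5ccccc5[nH]4)cc3F)ccnc2cc1OCCCN1CCCCC1` carries the change (1H-indol-2-yl in place of 4-hydroxyphenyl on a carbon with a double bond to nitrogen). The two measured replacements at the same carbon with a double bond to nitrogen, a 2.7-fold higher number from compound 1 to compound 2 (0.43 log units; beyond the scatter) and a 1.3-fold higher number from compound 1 to compound 3 (0.10 log units; within the scatter), shifted this assay by at most a modest amount, so compound 4 is expected to land near compound 3 in this assay, with no step beyond the scatter or at most a modest one in either direction. The expected outcome is a 1.2-fold lower number from compound 3 to compound 4 (0.07 log units; within the scatter). Compound 4 is therefore estimated at 400 nM, within a range from 150 nM to 1100 nM.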

Compound 4, half-maximal inhibitory concentration: 820 nM
For compound 4 the middle estimate is 2.1-fold (0.31 log units) below the measured one; the range from low to high includes it.
By their numbers in this assay, from the lowest: compounds 1, 3, 4 and 2 (each within the scatter of the next, the first and the last beyond it).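

At the carbon with a double bond to nitrogen, 1H-indol-2-yl brings in a five-membered aromatic ring with one hetero atom, and in this assay it gives a 1.7-fold higher number from compound 3 to compound 4 (0.24 log units; within the scatter) and a 1.2-fold lower number from compound 2 to compound 4 (0.09 log units; within the scatter), so neither of these two replacements separates from the scatter. Only the replacement of 2,4-dichlorophenyl reaches beyond the scatter, with a 2.2-fold higher number from compound 1 to compound 4 (0.35 log units; beyond the scatter), and that step is modest, so this two-ring group shifts the read-out here by no more than the single-ring groups do among themselves. Nothing at hand offers an explanation for these steps.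

The compounds shown leave open how a 1-methyl-1H-indol-2-yl group, a pyridyl ring or a phenyl ring carrying a carboxylic acid would behave at this carbon. They also leave open whether these small steps would hold in any read-out other than this assay.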